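Swapping the Amide for a Methoxy on the Shared Core

The source may report more compounds than this note shows. Statements on the series, on what has been measured and on what is new or still open speak of the compounds shown alone.

Of the compounds shown here, two built on one shared core have been tested in an ADME assay on MDBK cells (Bos taurus) for cytotoxicity, read by MTT assay, with a stated time of 96 h; a higher number here means that more compound is tolerated, a lower number that less compound is tolerated. Compound 1, `COc1ccc(-c2nc3cc(C(F)(F)F)ccc3[nH]2)c(OC)c1`, carries two methoxy groups on its outer ring. In this assay compound 1 gives > 100000 nM, which is a limit of the assay rather than a number. Compound 2, `CCC(=O)Nc1ccc(-c2nc3cc(C(F)(F)F)ccc3[nH]2)cc1`, carries a propanoylamino group instead. In this assay compound 2 gives > 100000 nM, again a limit of the assay and not a number. Compound 2 therefore stands at the top of what the assay can report, together with the other value shown: the limit of > 100000 nM in this assay, at which 2 of the 2 values shown sit.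

Compound 3, `COc1ccc(-c2nc3cc(C(F)(F)F)ccc3[nH]2)cc1`, has not yet been measured. It differs from compound 2 in one place: methoxy in place of propanoylamino on an aromatic carbon. Within the data shown here, no step between two measured compounds is available to anchor the size of this change. Since both measured values sit at the limit, compound 3 is expected to stay near it, with an expected step of a number no higher from compound 2 to compound 3 (the limit leaves the size open), which is none beyond the scatter. Compound 3 is estimated in this assay at 100000 nM, in the range 50000 nM to 300000 nM.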

Compound 3, half-maximal cytotoxic concentration: > 100000 nM
Compound 3: only a limit was reported; the forecaster's own chance of this, stated with the estimate: 80%; the middle value lies on the limit itself.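

In this assay compound 3 gives > 100000 nM, which is a limit of the assay and not a number. The steps from compound 1 and from compound 2 to compound 3 therefore cannot be read: the limit of > 100000 nM in this assay, at which 3 of the 3 values shown sit.

The compounds shown leave open how far their true values lie past this limit, and whether they differ from one another at all.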